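This account rests on a few compounds, and the source may have more. Where it says the series, first, only, none or still open, it means among the compounds named here.

In a functional assay on KB cells (Homo sapiens) for cytotoxicity (a higher number here means that more compound is needed for the effect, a lower number that less compound is needed), compound 3 (`CCc1ccc(/C=C/C(O)=C2/C(=O)C(C)=C(OC)C(C)(C)C2=O)cc1`) gives 1.9 ug/mL. That matches compound 1 (`COC1=C(C)C(=O)/C(=C(O)/C=C/c2ccc(Br)cc2)C(=O)C1(C)C`) at 1.9 ug/mL, and compound 2 (`COC1=C(C)C(=O)/C(=C(O)/C=C/c2ccc(O)cc2)C(=O)C1(C)C`) gives 3 ug/mL, so all three lie within the scatter of one another. The next structure, compound 4 (`COC1=C(C)C(=O)/C(=C(O)/C=C/c2ccco2)C(=O)C1(C)C`), keeps the shared core and changes the group at the end of the chain: furan-2-yl in place of 4-ethylphenyl on a double-bonded chain carbon bound to a double-bonded chain carbon.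

Among the measured compounds shown here, three measured steps bear on this change, though only indirectly. They are no change at the digits printed from compound 1 to compound 3 (within the scatter), a 1.6-fold higher number from compound 1 to compound 2 (0.20 log units; within the scatter) and a 1.6-fold lower number from compound 2 to compound 3 (0.20 log units; within the scatter). Each exchanges one group on an aromatic carbon, and none exceeds the scatter. Bromo, hydroxy and ethyl therefore leave this assay essentially unmoved across compound 1, compound 2 and compound 3. For the measured compounds named here, none of these steps replaces the whole aromatic group, however, and no furan-2-yl compound has yet been measured, so the evidence for the present change is thin. No shift beyond the scatter is expected, but the range should be kept wider than the spread of the three measured values.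

The expected step is a 1.3-fold higher number from compound 3 to compound 4 (0.12 log units; within the scatter). For compound 4 the estimated value is 2.5 ug/mL, with an expected range from 1 ug/mL to 6.5 ug/mL.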

Compound 4, concentration for half-maximal effect: 8.8 ug/mL
Compound 4: the middle estimate sits 3.5-fold (0.55 log units) below what was measured; the measured number lies above the stated range.
By their numbers in this assay, from the lowest: compounds 1, 3 and 2 (each within the scatter of the next); then compound 4.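

In this assay, among the compounds shown here, replacing the whole aromatic group at the end of the chain moves the number beyond the scatter for the first time: furan-2-yl gives a 4.6-fold higher number from compound 3 to compound 4 (0.67 log units; beyond the scatter) when it replaces 4-ethylphenyl and a 4.6-fold higher number from compound 1 to compound 4 (0.67 log units; beyond the scatter) when it replaces 4-bromophenyl, while its replacement of 4-hydroxyphenyl gives a 2.9-fold higher number from compound 2 to compound 4 (0.47 log units; beyond the scatter). The exchanges of bromo, hydroxy and ethyl on an aromatic carbon had stayed within the scatter, so among these four compounds the change of the aromatic group itself matters more at this position than the exchanges among those three groups on it, and none of the four goes against this, although the furan-2-yl side rests on compound 4 alone. Nothing shown here explains the step.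

From the compounds shown here alone, compound 4 differs from the three others at once in ring size, in its ring oxygen and in its heavy-atom count, so the share of each in the step remains open. Going by these compounds, whether a thiophene ring, a pyridine ring or an unsubstituted phenyl group at this place would read like compound 4 or like the compounds carrying a substituted phenyl group also remains open.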